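The compounds below may be only part of what the source reports. "The series", "measured", "known", "first", "only" and "open" are said of these compounds alone.

Compound 1 `O=C(c1cccc(F)c1)N(/N=N/c1ccc([N+](=O)[O-])cc1Cl)c1ccc([N+](=O)[O-])cc1Cl`: 2500 nM
Compound 2 `CC(=O)OCC(=O)N(/N=N/c1ccc([N+](=O)[O-])cc1Cl)c1ccc([N+](=O)[O-])cc1Cl`: 350 nM

In a functional assay on HeLa cells (Homo sapiens) for cytotoxicity, read by MTT assay, with a stated time of 72 h (a higher number here means a weaker inhibitor, a lower number a stronger inhibitor), compound 2 stands lowest of the two numbers measured; the step of a 7.1-fold lower number from compound 1 to compound 2 (0.85 log units; beyond the scatter) is the only one known. Compound 3 `COC(=O)N(/N=N/c1ccc([N+](=O)[O-])cc1Cl)c1ccc([N+](=O)[O-])cc1Cl` differs from compound 2 by methoxy in place of acetoxymethyl on a carbonyl carbon. That one measured step also exchanged the group on this carbonyl carbon and was modest, so a step of similar size or smaller is expected here, in either direction, with nothing in the data favouring one. Compound 3 is therefore expected near 500 nM in this assay, within 150 nM to 1800 nM, an expected step of a 1.4-fold higher number from compound 2 to compound 3 (0.15 log units; within the scatter).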

Compound 3, half-maximal inhibitory concentration: 980 nM
For compound 3 the middle estimate is 2.0-fold (0.29 log units) below the measured one; measured number inside the range.
By their numbers in this assay, from the lowest: compound 2; then compound 3; then compound 1.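

In this assay the step of a 2.8-fold higher number from compound 2 to compound 3 (0.45 log units; beyond the scatter) and the step of a 2.6-fold lower number from compound 1 to compound 3 (0.41 log units; beyond the scatter) place methoxy between acetoxymethyl and 3-fluorophenyl on this carbonyl carbon. The three groups now give three distinct numbers, so the choice of group here clearly counts, and going from the 5 heavy atoms of acetoxymethyl to the 2 of methoxy does not lower the number. Nothing measured here explains this order.

On these data alone, whether an amine or a longer chain on this carbonyl carbon would fall below compound 2 remains open.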